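A few compounds are considered here, and "the series" means these few. Any claim that something is new, unique, unknown or untested is made for them only; others in the source may bear on it.

Measured in a functional assay on MCF7 cells (Homo sapiens) for antiproliferative activity, read by MTT assay, with a stated time of 72 h; a lower number here means a stronger inhibitor, a higher number a weaker inhibitor:
Compound 1 `O=C(N/N=C/c1ccccc1)Nc1ccc(Oc2ccnc3[nH]ccc23)c(F)c1`: 2380 nM
Compound 2 `O=C(N/N=C/c1ccc(F)cc1)Nc1ccc(Oc2ccnc3[nH]ccc23)c(F)c1`: 800 nM
Compound 3 `O=C(N/N=C/c1ccc([N+](=O)[O-])cc1)Nc1ccc(Oc2ccnc3[nH]ccc23)c(F)c1`: 4000 nM

The data show a 5.0-fold higher number from compound 2 to compound 3 (0.70 log units; beyond the scatter), but also a 1.7-fold higher number from compound 1 to compound 3 (0.23 log units; within the scatter), so compound 3 shares the upper end of the range with compound 1. Compound 4 `O=C(N/N=C/c1ccc(O)cc1O)Nc1ccc(Oc2ccnc3[nH]ccc23)c(F)c1` brings this change: 2,4-dihydroxyphenyl in place of 4-nitrophenyl on a carbon with a double bond to nitrogen. In words, 2,4-dihydroxyphenyl stands in place of 4-nitrophenyl. For the measured compounds named here, no measured compound carries hydroxyl groups, so the evidence is indirect. Nitro in place of hydrogen gave a 1.7-fold higher number from compound 1 to compound 3 (0.23 log units; within the scatter), while fluoro in place of hydrogen gave a 3.0-fold lower number from compound 1 to compound 2 (0.47 log units; beyond the scatter). Steps in this group have thus stayed modest, and a small drop in this assay, not clearly beyond the scatter, is expected. The estimated step is a 2.0-fold lower number from compound 3 to compound 4 (0.30 log units; within the scatter). For compound 4 the expected value is 2000 nM, with an estimated range of 700 nM to 6000 nM.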

Compound 4, half-maximal inhibitory concentration: 48000 nM
Compound 4: middle estimate off by 24-fold (1.38 log units), on the low side; the measured number lies above the stated range.
By their numbers in this assay, from the lowest: compound 2; then compounds 1 and 3 (each within the scatter of the next); then compound 4.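

In this assay, 2,4-dihydroxyphenyl on the carbon with a double bond to nitrogen gives a 12-fold higher number from compound 3 to compound 4 (1.08 log units; beyond the scatter) as well as a 20-fold higher number from compound 1 to compound 4 (1.30 log units; beyond the scatter) and a 60-fold higher number from compound 2 to compound 4 (1.78 log units; beyond the scatter) and so makes compound 4 the weakest of the four. Among phenyl, 4-fluorophenyl and 4-nitrophenyl no step had gone beyond modest, so this position can respond far more sharply than those compounds showed.

From the compounds shown here alone, whether a methoxy group or an amine on the phenyl ring would behave like the two hydroxyl groups stays open. Nothing measured here accounts for the large loss.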